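Chloro to Fluoro: an Expectation for Compound 3

This account rests on a few compounds, and the source may have more. Where it says the series, first, only, none or still open, it means among the compounds named here.

Of the compounds shown here, two have been measured so far in a functional assay on A549 cells (Homo sapiens) for antiproliferative activity, read by MTT assay, with a stated time of 72 h; on this read-out lower numbers stand for stronger inhibition and higher numbers for weaker inhibition. Compound 2 `COc1cc2ncnc(Nc3cccc(Cl)c3)c2cc1OCCCCC(=O)Nc1ccc(S(N)(=O)=O)cc1` gives 11200 nM in this assay. Among the measured compounds shown here, its only neighbour, compound 1 `COc1cc2ncnc(Nc3ccc(F)c(Cl)c3)c2cc1OCCCCC(=O)Nc1ccc(S(N)(=O)=O)cc1`, gives 15500 nM in this assay, and the two numbers lie within the scatter of each other. For the measured compounds named here, the single measured step, a 1.4-fold lower number from compound 1 to compound 2 (0.14 log units; within the scatter), concerns hydrogen in place of fluoro.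

Compound 3 `COc1cc2ncnc(Nc3cccc(F)c3)c2cc1OCCCCC(=O)Nc1ccc(S(N)(=O)=O)cc1` has not yet been measured. It differs from compound 2 by fluoro in place of chloro on an aromatic carbon. Going by the values given here, no measured pair shows an exchange of chloro for fluoro, so the one known step bears on it only indirectly, by showing that a halogen change on this ring left the number within the scatter. Compound 3 is therefore expected to show a step of a 1.3-fold higher number from compound 2 to compound 3 (0.10 log units; within the scatter), not beyond the scatter in either direction. The estimate for compound 3 in this assay is 14000 nM, with a range from 6000 nM to 35000 nM.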

Compound 3, half-maximal inhibitory concentration: > 40000 nM
Compound 3 was reported as a limit (the forecaster's own chance of this, stated with the estimate: 5%); at least 2.8-fold (0.45 log units) between middle value and limit.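

The exchange of chloro for fluoro at this place, meta to a large group, is the first change shown to move the number beyond the scatter, with an at least 3.5-fold higher number from compound 2 to compound 3 (0.55 log units; beyond the scatter) in this assay while a 1.4-fold lower number from compound 1 to compound 2 (0.14 log units; within the scatter) stays within it. The other neighbour points the same way, with an at least 2.5-fold higher number from compound 1 to compound 3 (0.41 log units; beyond the scatter) when 3-fluorophenyl replaces 3-chloro-4-fluorophenyl, so among these compounds the two that carry chloro give numbers and the one without it does not. Compound 3 stands only as a limit and not as a number: the limit of > 40000 nM in this assay, at which 1 of the 3 values shown sits.

On these data alone, the full size of both new steps therefore remains open. Also open, as far as these compounds go, is whether bromo, methyl or an amine at this place would keep the number close to that of compound 2, and whether a longer chain would alter the effect of this exchange.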